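The compounds below may be only part of what the source reports. "The series", "measured", "known", "first", "only" and "open" are said of these compounds alone.

Measured compounds in a functional assay on the whole organism (strain Albino Wistar) for inhibition, with Rattus norvegicus as the target, read by paw edema, with stated times of 1 h and 5 h, at a dose of 10 mg/kg by the oral route; on this read-out lower numbers stand for less inhibition and higher numbers for more inhibition at the one dose given (going by the name of the read-out):

- compound 1, `Clc1ccc(-n2cc(CSc3nc4ccccc4s3)nn2)cc1`: 43.4%
- compound 2, `CCOc1ccc(-n2cc(CSc3nc4ccccc4s3)nn2)cc1`: 34%

Among the compounds with values here, compound 2 holds the lower of the two numbers recorded so far, the nearest neighbour being compound 1, and the single step between them, a number 9.4 percentage points lower from compound 1 to compound 2 (within the scatter), stays within the scatter, so neither compound can be ordered above the other on this read-out.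

Compound 3, `c1ccc(-n2cc(CSc3nc4ccccc4s3)nn2)cc1`, remains to be measured in this assay. Within the data shown here, it departs from compound 2 by a change at the same aromatic carbon that was already varied in the one measured step: hydrogen in place of ethoxy on an aromatic carbon. Among the measured compounds shown here, the only step that bears on it is the chloro-to-ethoxy change, which produced no shift beyond the scatter. Nothing recorded speaks for a sizeable step in either direction, so no change beyond the scatter is expected for compound 3.

The number estimated for compound 3 is 38%, with a range from 24% to 52%; this expectation implies a number 4 percentage points higher from compound 2 to compound 3 (within the scatter).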

Compound 3, a percentage reported as inhibition, in the whole organism at one dose (the size of the read-out at that dose, not a potency): 32.1%
For compound 3 the middle estimate is 5.9 percentage points above the measured one; the range from low to high includes it.
By their numbers in this assay, from the lowest: compounds 3, 2 and 1 (each within the scatter of the next, the first and the last beyond it).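

Replacing ethoxy with hydrogen on this aromatic carbon, para to a large group, gives a number 1.9 percentage points lower from compound 2 to compound 3 (within the scatter) in this assay and does not separate the two compounds on this read-out. Within the data shown here, replacing chloro with hydrogen at the same carbon gives a number 11.3 percentage points lower from compound 1 to compound 3 (beyond the scatter) and is the only step in the set beyond the scatter, though a modest one, so here chloro stands apart from hydrogen while ethoxy stands apart from neither. Nothing on hand accounts for this difference. Going by these compounds, whether the gap from hydrogen is particular to chloro or also appears with bromo, an amine or a carboxylic acid at this carbon remains open. On these data alone, how changes elsewhere on the shared core would register in this assay also remains open, as all three compounds vary at this one carbon only.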